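This account rests on a few compounds, and the source may have more. Where it says the series, first, only, none or still open, it means among the compounds named here.

Measured in a functional assay on K562 cells (Homo sapiens) for cytotoxicity, read by trypan blue exclusion, with a stated time of 96 h; on this read-out lower numbers stand for stronger inhibition and higher numbers for weaker inhibition:
- compound 1 `COc1ccc(/C=C/S(=O)(=O)Cc2ccc(OC)c(N)c2)c(OC)c1`: 500 nM
- compound 2 `COc1ccc(CS(=O)(=O)/C=C/c2c(OC)cccc2OC)cc1N`: 50 nM
- compound 3 `COc1ccc(CS(=O)(=O)/C=C/c2c(OC)cc(OC)cc2OC)c(N)c1`: 25 nM

Compound 3, at 25 nM, sits within the usual scatter of compound 2, at 50 nM. Both numbers lie well clear of compound 1, at 500 nM, a gap beyond the scatter.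

Compound 4 `COc1cc(OC)c(/C=C/S(=O)(=O)Cc2ccc(OC)c(N)c2)c(OC)c1` has not yet been measured. It keeps the atoms of compound 3 but joins them differently, with 3-amino-4-methoxyphenyl in place of 2-amino-4-methoxyphenyl on a saturated chain carbon bound to a sulfonyl sulfur.

Among the measured compounds shown here, no measured pair isolates this swap, so the evidence is indirect. Compound 2, which carries the entering group, gives 50 nM, a number close to that of compound 3. Compound 1 carries the same group yet gives 500 nM, so the group alone does not guarantee a low number. The rest of compound 4 matches compound 3, so no change beyond the scatter is expected. The expected step is a 1.3-fold lower number from compound 3 to compound 4 (0.10 log units; within the scatter). The estimate for compound 4 is 20 nM, with an expected range of 6 nM to 80 nM.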

Compound 4, half-maximal inhibitory concentration: 2.5 nM
For compound 4 the middle estimate is 8.0-fold (0.90 log units) above the measured one, outside the stated range (below it).
By their numbers in this assay, from the lowest: compound 4; then compounds 3 and 2 (each within the scatter of the next); then compound 1.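

Having 3-amino-4-methoxyphenyl in place of 2-amino-4-methoxyphenyl on a saturated chain carbon bound to a sulfonyl sulfur gives a 10-fold lower number from compound 3 to compound 4 (1.00 log units; beyond the scatter) in this assay and shows that the arrangement of the atoms matters here, since the two groups hold the same atoms. Methoxy in place of hydrogen on an aromatic carbon is also a strong change: it gives a 20-fold lower number from compound 2 to compound 4 (1.30 log units; beyond the scatter) and a 200-fold lower number from compound 1 to compound 4 (2.30 log units; beyond the scatter) as well. These two steps differ in size, so the effect of this methoxy depends on which aromatic carbon receives it.

On these data alone, whether a hydroxyl or a dimethylamino group could stand in place of the amino group and keep such a low number remains open. Nothing shown here explains why these steps are so large.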